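The source may report more compounds than this note shows. Statements on the series, on what has been measured and on what is new or still open speak of the compounds shown alone.

In a functional assay on MGC-803 cells (Homo sapiens) for antiproliferative activity, read by MTT assay, with a stated time of 72 h (a lower number here means a stronger inhibitor, a higher number a weaker inhibitor), compound 1 (`COc1ccc(-n2nc(-c3ccccc3)nc2CNc2ccc(C(=O)NO)cc2)cc1`) gives 7050 nM, compound 2 (`O=C(NO)c1ccc(NCc2nc(-c3ccc(Cl)cc3)nn2-c2ccccc2)cc1`) gives 5970 nM and compound 3 (`O=C(NO)c1ccc(NCc2nc(-c3ccc(F)cc3)nn2-c2ccccc2)cc1`) gives 8960 nM. These three numbers lie within the usual scatter of one another, so compound 3 stands level with the other two. Compound 4 (`O=C(NO)c1ccc(NCc2nc(-c3ccccc3)nn2-c2ccccc2)cc1`) differs from compound 3 by one change, hydrogen in place of fluoro on an aromatic carbon, para to a large group: hydrogen in place of fluoro on an aromatic carbon. For the measured compounds named here, the one measured step of this kind, fluoro in place of chloro on an aromatic carbon, is a 1.5-fold higher number from compound 2 to compound 3 (0.18 log units; within the scatter). No step beyond the scatter is therefore expected in this assay, and the estimated step is a 1.2-fold lower number from compound 3 to compound 4 (0.08 log units; within the scatter). For compound 4 the estimated value is 7500 nM, with an expected range from 3700 nM to 15000 nM.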

Compound 4, half-maximal inhibitory concentration: 17700 nM
Compound 4: middle estimate off by 2.4-fold (0.37 log units), on the low side; the measured number lies above the stated range.
By their numbers in this assay, from the lowest: compounds 2, 1, 3 and 4 (each within the scatter of the next, the first and the last beyond it).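

In this assay, for the compounds shown here, the earlier compounds showed no step beyond the scatter, but losing the ring substituent now does so twice: hydrogen in place of chloro (a 3.0-fold higher number from compound 2 to compound 4 (0.47 log units; beyond the scatter)) and hydrogen in place of methoxy (a 2.5-fold higher number from compound 1 to compound 4 (0.40 log units; beyond the scatter)). Both steps are modest and point towards a higher number, meaning a weaker inhibitor. Hydrogen in place of fluoro (a 2.0-fold higher number from compound 3 to compound 4 (0.30 log units; within the scatter)) stays within the scatter, so compound 4 stands level with compound 3.

Nothing shown gives a reason for these steps. As far as these compounds go, whether an amine or a carboxylic acid at this place would stand level with chloro and fluoro remains open.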